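A Hydroxy Group Added to a Fluorophenyl Enone

The source may hold more compounds than are shown below. What is called first, only, known or untested is meant among the compounds shown, and "the series" means these compounds.

Measured in a functional assay on LNCaP cells (Homo sapiens) for cytotoxicity, read by MTT assay, with a stated time of 72 h; on this read-out lower numbers stand for stronger inhibition and higher numbers for weaker inhibition:
compound 1 `CC1=C(/C=C/C(=O)/C=C/c2ccccc2F)C(C)(C)CCC1` 10700 nM
compound 2 `CC1=C(/C=C/C(=O)/C=C/c2cccc(F)c2)C(C)(C)CCC1` 12900 nM
compound 3 `CC1=C(/C=C/C(=O)/C=C/c2ccc(F)cc2)C(C)(C)CCC1` 7300 nM

Compound 1 stands among these values with no separation beyond the scatter, since its steps are a 1.2-fold higher number from compound 1 to compound 2 (0.08 log units; within the scatter) and a 1.5-fold lower number from compound 1 to compound 3 (0.17 log units; within the scatter). The remaining step is a 1.8-fold lower number from compound 2 to compound 3 (0.25 log units; within the scatter). All of these steps exchange 2-fluorophenyl, 3-fluorophenyl and 4-fluorophenyl, and none alters the saturated ring of the shared core. They therefore give no direct measure of the next change.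

Compound 4 `CC1=C(/C=C/C(=O)/C=C/c2ccccc2F)C(C)(C)CCC1O` differs from compound 1 by hydroxy in place of hydrogen on a saturated ring carbon, next to the ring atom that bears a methyl group (hydroxy in place of hydrogen on a saturated ring carbon). For the measured compounds named here, with no measured example of this change, no direction is firmly indicated, and no step beyond the scatter is expected in this assay. The expected step is a 1.1-fold higher number from compound 1 to compound 4 (0.05 log units; within the scatter). Compound 4 is estimated at 12000 nM, with an expected range from 5000 nM to 30000 nM.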

Compound 4, half-maximal inhibitory concentration: 2900 nM
Compound 4: middle estimate off by 4.1-fold (0.62 log units), on the high side, and the stated range ends above it.
By their numbers in this assay, from the lowest: compound 4; then compounds 3, 1 and 2 (each within the scatter of the next).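

In this assay, hydroxy in place of hydrogen on this saturated ring carbon produces a modest step (a 3.7-fold lower number from compound 1 to compound 4 (0.57 log units; beyond the scatter)). The exchanges of 2-fluorophenyl, 3-fluorophenyl and 4-fluorophenyl among compound 1, compound 2 and compound 3 all stayed within the scatter and left the saturated ring unchanged, so this is the only step shown that lies beyond the scatter, and it shows that the number responds to a change at this ring carbon. No measurement shown explains why the number falls.

The compounds shown leave open whether a methoxy group, an amine or a ketone on the same ring carbon would give a similar step. They also leave open whether hydroxy would have the same effect alongside 3-fluorophenyl or 4-fluorophenyl, or on another saturated ring carbon.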